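The source may hold more compounds than are shown below. What is called first, only, known or untested is meant among the compounds shown, and "the series" means these compounds.

Two compounds share a core in which a saturated ring holding a sulfur atom and an amide-type nitrogen carries an ether-linked aromatic ring. Compound 1, `CCOC(=O)CC(=O)N1CCSC1COc1ccccc1OC`, was tested in a functional assay on the whole organism (trachea) for inhibition, with Cavia porcellus as the target (a lower number here means that less compound is needed, a higher number that more compound is needed for the effect), where compound 1 gives 11 mg/kg. Compound 2, `CCOC(=O)CC(=O)N1CC[S+]([O-])C1COc1ccccc1OC`, differs in having an oxygen on the ring sulfur; in this assay compound 2 gives 28 mg/kg. Of these two numbers, compound 1 holds the lowest, and compound 2 stands a step higher that lies beyond the usual scatter.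

Compound 3, `COc1ccccc1OCC1SCCN1C(=O)C(C)(C)C(=O)O`, has not yet been measured. It keeps the ring and the aromatic arm of compound 1 but rebuilds the side chain on the amide carbonyl: 1-carboxy-1-methylethyl in place of (ethoxycarbonyl)methyl on a carbonyl carbon. The same atoms are joined differently, so the chain keeps its size while gaining a hydrogen-bond donor. Within the data shown here, no measured pair shows a change of this kind, and the direction of its effect is unknown. The estimated step of a 1.8-fold higher number from compound 1 to compound 3 (0.26 log units; within the scatter) is expected to be modest, toward a higher number. For compound 3 the estimate in this assay is 20 mg/kg, with a range from 6 mg/kg to 60 mg/kg.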

Compound 3, dose for half-maximal effect: 21 mg/kg
Beside the measured number, compound 3's estimate is 1.1-fold (0.02 log units) below it, and the stated range covers the measured number.
By their numbers in this assay, from the lowest: compounds 1, 3 and 2 (each within the scatter of the next, the first and the last beyond it).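

In this assay, putting 1-carboxy-1-methylethyl in place of (ethoxycarbonyl)methyl on a carbonyl carbon gives a 1.9-fold higher number from compound 1 to compound 3 (0.28 log units; within the scatter) and so leaves the two compounds indistinguishable in this measurement. The earlier pair differed only at the ring sulfur and said nothing about this side chain, whereas this result shows that the position accepts a rearrangement of the same atoms, including the gain of a hydrogen-bond donor, without a change that stands out from the scatter. The data shown offer no independent measurement that could explain this outcome.

The swap alters the order of the atoms and the hydrogen-bond donor count together, so the compounds shown cannot separate the contribution of either one. From the compounds shown here alone, it also remains open whether an amine or a longer chain on the same carbonyl carbon would fit equally well, and whether 1-carboxy-1-methylethyl would give a similar number when the ring sulfur carries an oxygen, as it does in compound 2.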